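This account rests on a few compounds, and the source may have more. Where it says the series, first, only, none or still open, it means among the compounds named here.

Measured in an ADME assay on MDBK cells (Bos taurus) for cytotoxicity, read by MTT assay, with a stated time of 96 h; a lower number here means that less compound is tolerated, a higher number that more compound is tolerated:
- Compound 1 `Cn1c(-c2ccc([N+](=O)[O-])cc2)nc2cc(C(F)(F)F)ccc21` gives > 100000 nM. This is a limit of the assay, not a number.
- Compound 2 `O=[N+]([O-])c1ccc(-c2nc3cc(C(F)(F)F)ccc3n2C2CCCCC2)cc1` gives 68000 nM.

Compound 1 stands at the top of what this assay can report: only a limit is known for it, (the limit of > 100000 nM in this assay, at which 1 of the 2 values shown sits), so its true tolerance may lie anywhere at or beyond that mark. Going by the values given here, the single measured step, an at least 1.4-fold lower number from compound 1 to compound 2 (0.16 log units; that floor lies within the scatter), changes the group on the aromatic nitrogen rather than the group on the six-membered carbon ring, and its floor falls inside the usual scatter; it therefore says little about substituent effects at the position now in question and nothing about the direction of a change there.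

Compound 3 `CCC(=O)Nc1ccc(-c2nc3cc(C(F)(F)F)ccc3n2C)cc1` differs from compound 1 by propanoylamino in place of nitro on an aromatic carbon. Among the compounds with values here, no measured step touches this position, so there is no basis for expecting a shift beyond the scatter in this assay. The working expectation is that compound 3 remains about where compound 1 sits, with the real chance that the assay again reports only a limit. Compound 3 is estimated at 100000 nM, with a range from 40000 nM to 250000 nM. The expected step is a number no higher from compound 1 to compound 3 (the limit leaves the size open).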

Compound 3, half-maximal cytotoxic concentration: > 100000 nM
Compound 3 was reported as a limit (the forecaster's own chance of this, stated with the estimate: 55%); the middle value sits exactly at the limit.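

In this assay, going by these compounds alone, compound 1 and compound 3 are both reported only as limits, so no step between them can be read: the limit of > 100000 nM in this assay, at which 2 of the 3 values shown sit.

Still open, on these data alone, is whether propanoylamino in place of nitro on an aromatic carbon changes the tolerated concentration at all, in which direction, and how far either compound lies past that limit.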